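Replacing a Side Group on a Double-Bonded Nitrogen

A few compounds are considered here, and "the series" means these few. Any claim that something is new, unique, unknown or untested is made for them only; others in the source may bear on it.

Of the compounds shown here, three sharing a common core have been measured in a physicochemical assay for lipophilicity, using the shake flask method; a lower number here means a more polar compound, a higher number a more lipophilic compound. Compound 1 `C#CCO/N=C/c1c(N)ncnc1Oc1ccc(NC(=O)C2(C(=O)Nc3ccc(F)cc3)CC2)cc1F` gives 3.34, compound 2 `CC(C)(C)OC(=O)N/N=C/c1c(N)ncnc1Oc1ccc(NC(=O)C2(C(=O)Nc3ccc(F)cc3)CC2)cc1F` gives 3.7, and compound 3 `CNc1ncnc(Oc2ccc(NC(=O)C3(C(=O)Nc4ccc(F)cc4)CC3)cc2F)c1/C=N/OC` gives 3.52. Compound 2 thus stands within the scatter of compound 3 and beyond the scatter of compound 1.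

The step followed here leads from compound 2 to compound 4 `CCCCO/N=C/c1c(N)ncnc1Oc1ccc(NC(=O)C2(C(=O)Nc3ccc(F)cc3)CC2)cc1F`, which has not yet been measured in this assay. The structural change is butoxy in place of (tert-butoxycarbonyl)amino on a double-bonded nitrogen.

Among the measured compounds shown here, only one measured step bears directly on this change: a number 0.36 log units higher from compound 1 to compound 2 (beyond the scatter). That modest step has (tert-butoxycarbonyl)amino entering in place of propargyloxy, so read in reverse it would point to a lower number once that group leaves. However, butoxy is not propargyloxy, and no measured compound carries butoxy, so the step cannot simply be reversed. Compound 3 differs from compound 4 in more than one place and offers only a loose guide.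

The expected change is a number 0.15 log units higher from compound 2 to compound 4 (within the scatter), which is estimated to stay within the scatter. For compound 4 the estimated value is 3.85, with an expected range from 3.5 to 4.2.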

Compound 4, partition coefficient: 4.2
Beside the measured number, compound 4's estimate is 0.35 log units below it, and the stated range covers the measured number.
By their numbers in this assay, from the lowest: compounds 1, 3 and 2 (each within the scatter of the next, the first and the last beyond it); then compound 4.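

In this assay, the position on a double-bonded nitrogen now shows that compound 2 is not the upper end of the series: butoxy in place of (tert-butoxycarbonyl)amino gives a number 0.50 log units higher from compound 2 to compound 4 (beyond the scatter), even though butoxy has 5 heavy atoms against 8 in the group it replaces, and no hydrogen-bond donor against 1. A change further out on the chain also counts, since propyl in place of ethynyl on a saturated chain carbon bound to an oxygen gives a number 0.86 log units higher from compound 1 to compound 4 (beyond the scatter), so two side groups joined through oxygen at this position can stand clearly apart. Nothing at hand accounts for either step.

Because butoxy differs from (tert-butoxycarbonyl)amino in several counted features at once, the compounds shown do not separate the part played by chain size from that of the hydrogen-bond donor. They also leave open whether a shorter chain such as ethoxy, a longer chain such as hexyloxy, or a butoxy chain ending in an amine or a carboxylic acid would move the number further, and whether butoxy would behave the same way alongside the methylamino group of compound 3.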